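The compounds below may be only part of what the source reports. "The series", "measured", "known", "first", "only" and "open" are said of these compounds alone.

Of the compounds shown here, two have so far been measured in an ADME assay on the whole organism (Rattus norvegicus, strain Sprague-Dawley) for pharmacokinetics, read by LC-MS, with a stated time of 24 h, at a dose of 1 mg/kg by the intravenous route; a lower number here means less compound in the circulation, a higher number more compound in the circulation at the dose given. Compound 1 `Cn1nccc1-c1cc(C(F)(F)F)ccc1[C@H]1CCc2cc(S(=O)(=O)Nc3ncccn3)ccc21` carries a 1-methyl-1H-pyrazol-5-yl group on one core, and in this assay compound 1 gives 2500 nM. Compound 2 `O=S(=O)(Nc1ncccn1)c1ccc2c(c1)OCC[C@@H]2c1ccc(C(F)(F)F)cc1-c1ccc(F)nc1` carries a 6-fluoropyridin-3-yl group on a related core, and in this assay compound 2 gives 1700 nM. Compound 2 has the lower of the two numbers, but the gap to compound 1 is within the usual scatter of repeated measurements, so the two cannot be told apart on these data.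

Compound 3 `Cn1nccc1-c1cc(C(F)(F)F)ccc1[C@H]1CCOc2cc(S(=O)(=O)Nc3ncccn3)ccc21` has not yet been measured. It keeps the core of compound 2 and differs from it in one place (1-methyl-1H-pyrazol-5-yl in place of 6-fluoropyridin-3-yl on an aromatic carbon). Going by the values given here, no measured pair shows the effect of this exact change on the same core, so the expectation rests on compound 1, which carries the entering group and gives 2500 nM, a number close to that of compound 2. The step of a 1.3-fold higher number from compound 2 to compound 3 (0.11 log units; within the scatter) is therefore expected to be small, within the scatter, if anything a slight rise. For compound 3 in this assay the estimate is 2200 nM, with a range from 1200 nM to 4500 nM.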

Compound 3, maximal plasma concentration in the Rattus norvegicus assay: 2200 nM
Compound 3: the middle estimate sits on the measured number at the digits printed; measured number inside the range.
By their numbers in the Rattus norvegicus assay, from the lowest: compounds 2, 3 and 1 (each within the scatter of the next).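

In the Rattus norvegicus assay, exchanging 6-fluoropyridin-3-yl for 1-methyl-1H-pyrazol-5-yl, on an aromatic carbon ortho to a large group and meta to a trifluoromethyl group, gives a 1.3-fold higher number from compound 2 to compound 3 (0.11 log units; within the scatter), so this one pair on a single core shows no readable difference between the two rings at this position. A second read-out does separate them: in a physicochemical assay for lipophilicity (on this read-out lower numbers stand for lower lipophilicity and higher numbers for higher lipophilicity), compound 2 gives 2.8 and compound 3 gives 3.7. In the physicochemical assay that is a number 0.90 log units higher from compound 2 to compound 3 (beyond the scatter), so at this position a clear shift on one read-out comes with no readable shift in the Rattus norvegicus assay.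

As far as these compounds go, whether that holds for groups of a different kind at this position, such as an amine, a carboxylic acid or a longer chain, stays open, as does the question of whether any group here can move the number in the Rattus norvegicus assay beyond the scatter. Also open, from the compounds shown here alone, is whether the 6-fluoropyridin-3-yl group would give the same picture on the core of compound 1, since a single exchange on one core cannot say how far the result carries.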